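Swapping the amine on a dinitrobenzene bis-diazeniumdiolate

The source may report more compounds than this note shows. Statements on the series, on what has been measured and on what is new or still open speak of the compounds shown alone.

Measured compounds:
compound 1, `CN(C)/[N+]([O-])=N/Oc1cc(O/N=[N+](\[O-])N2CCCC2CO)c([N+](=O)[O-])cc1[N+](=O)[O-]`: 1000 nM
compound 2, `CCN(CC)/[N+]([O-])=N/Oc1cc(O/N=[N+](\[O-])N(C)C)c([N+](=O)[O-])cc1[N+](=O)[O-]`: 1000 nM
compound 3, `CCOC(=O)N1CCN(/[N+]([O-])=N/Oc2cc(O/N=[N+](\[O-])N(CC)CC)c([N+](=O)[O-])cc2[N+](=O)[O-])CC1`: 2100 nM

In a functional assay on HL-60 cells (Homo sapiens) for antiproliferative activity, read by MTT assay, with a stated time of 72 h (on this read-out lower numbers stand for stronger inhibition and higher numbers for weaker inhibition), compound 3 gives the highest number of the three. The step of a 2.1-fold higher number from compound 2 to compound 3 (0.32 log units; beyond the scatter) lies beyond the scatter, whereas the step of no change at the digits printed from compound 1 to compound 2 (within the scatter) does not. Compound 4, `CCN(CC)/[N+]([O-])=N/Oc1cc(O/N=[N+](\[O-])N2CCCC2CO)c([N+](=O)[O-])cc1[N+](=O)[O-]`, differs from compound 3 by 2-(hydroxymethyl)pyrrolidin-1-yl in place of 4-(ethoxycarbonyl)piperazin-1-yl on a double-bonded nitrogen. The change undoes the entry of the piperazine seen in the step from compound 2 to compound 3, and the hydroxymethylpyrrolidinyl that enters was present in compound 1 without effect against compound 2. A modest fall toward the numbers of compounds 1 and 2 is therefore expected, as a 1.9-fold lower number from compound 3 to compound 4 (0.28 log units; within the scatter). Compound 4 is expected to give about 1100 nM, with a likely range from 500 nM to 2500 nM.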

Compound 4, half-maximal inhibitory concentration: 1800 nM
Compound 4: the middle estimate sits 1.6-fold (0.21 log units) below what was measured; the range from low to high includes it.
By their numbers in this assay, from the lowest: compounds 1, 2, 4 and 3 (each within the scatter of the next, the first and the last beyond it).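

In this assay, with diethylamino kept on the other side, 2-(hydroxymethyl)pyrrolidin-1-yl in place of 4-(ethoxycarbonyl)piperazin-1-yl gives a 1.2-fold lower number from compound 3 to compound 4 (0.07 log units; within the scatter), and in place of dimethylamino it gives a 1.8-fold higher number from compound 2 to compound 4 (0.26 log units; within the scatter). Compound 4 therefore lies within the scatter of both compound 2 and compound 3, although those two lie beyond it from each other. Diethylamino in place of dimethylamino on the partner nitrogen gives a 1.8-fold higher number from compound 1 to compound 4 (0.26 log units; within the scatter), so that exchange also stays within the scatter. Nothing available here accounts for these numbers. From the compounds shown here alone, what a morpholine or an unsubstituted piperazine on this double-bonded nitrogen would give remains open.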